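Trading a tert-butyl group for methyl

The compounds below may be only part of what the source reports. "The series", "measured", "known", "first", "only" and "open" are said of these compounds alone.

Compound 1 `C[Se]C(=O)c1cccc(C(=O)[Se]C)n1`: > 100000 nM (a limit)
Compound 2 `CC(C)(C)C(=O)C[Se]C(=O)c1ccc(Cl)cc1`: 960 nM

For the measured compounds named here, both compounds were tested in a functional assay on COLO 320 cells (Homo sapiens) for cytotoxicity, read by MTT assay, with a stated time of 24 h (on this read-out higher numbers stand for weaker inhibition and lower numbers for stronger inhibition), and only one gave a true number. Compound 1 reads > 100000 nM and this is a limit, not a number. Going by the values given here, compound 2 holds the only number so far, at 960 nM in this test. Compound 3 `CC(=O)C[Se]C(=O)c1ccc(Cl)cc1` has methyl in place of tert-butyl on a carbonyl carbon and is otherwise the same. Among the compounds with values here, no measured step guides this change, so only a modest shift toward weaker inhibition is expected in this assay here. Compound 3 is estimated at 1500 nM with 400 nM to 6000 nM as its expected range.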

Compound 3, half-maximal inhibitory concentration: 550 nM
Estimate against measurement, compound 3: 2.7-fold (0.44 log units) above; measured number inside the range.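

In this assay the swap of tert-butyl for methyl on this carbonyl carbon gives a 1.7-fold lower number from compound 2 to compound 3 (0.24 log units; within the scatter) and so counts as no real change. At this position, a group of 4 heavy atoms and a group of 1 heavy atom read alike, so the tert-butyl group is not needed to keep this level of cytotoxicity. Nothing measured here bears on why the two compounds read alike. As far as these compounds go, whether an amine or a carboxylic acid on this carbonyl carbon would also read alike remains open.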